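A larger side chain on compound 2

The source may report more compounds than this note shows. Statements on the series, on what has been measured and on what is new or still open speak of the compounds shown alone.

Values so far in a physicochemical assay for solubility, in phosphate buffer, at pH 6.5; a lower number here means a less soluble compound, a higher number a more soluble compound:
- compound 1 (`CC(C)(C)c1ccccc1Oc1ncccc1NC(=O)Nc1ccc(-c2ccccc2CO)cc1F`) gives 2 ug/mL
- compound 2 (`CC(C)(C)c1ccccc1Oc1ncccc1NC(=O)Nc1ccc(N2CCCCC2)cc1`) gives 9 ug/mL
- compound 3 (`CC(C)(C)c1ccccc1Oc1ncccc1NC(=O)Nc1ccc(OCC2CCN(Cc3ccccc3)CC2)cc1F`) gives 2 ug/mL

Compound 2 stands highest of these three. Compound 1 and compound 3 both sit lower, by a gap beyond the scatter. Each of the three differs from the others in more than one place, so no clean single-change comparison exists yet.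

Compound 4 (`CC(C)CN1CCC(COc2ccc(NC(=O)Nc3cccnc3Oc3ccccc3C(C)(C)C)cc2)CC1`) has not been measured. It departs from compound 2 in one place: (1-isobutylpiperidin-4-yl)methoxy in place of piperidin-1-yl on an aromatic carbon. In words, this is (1-isobutylpiperidin-4-yl)methoxy in place of piperidin-1-yl on an aromatic carbon.

The nearest guide is compound 3 at 2 ug/mL whose side chain resembles the entering group, though it differs elsewhere too. That pulls the expectation down from compound 2, but only slightly, since the two groups are not the same. No step beyond the scatter is expected, and the estimate is a 1.8-fold lower number from compound 2 to compound 4 (0.26 log units; within the scatter) in this assay here. Compound 4 is estimated at 5 ug/mL with an expected range from 1 ug/mL to 25 ug/mL (an estimate until measured).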

Compound 4, solubility: 27 ug/mL
Estimate against measurement, compound 4: 5.4-fold (0.73 log units) below, outside the stated range (above it).
By their numbers in this assay, from the lowest: compounds 1 and 3 (each within the scatter of the next); then compound 2; then compound 4.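

In this assay, for the compounds shown here, the swap of piperidin-1-yl for (1-isobutylpiperidin-4-yl)methoxy, on an aromatic carbon para to a large group, gives a 3.0-fold higher number from compound 2 to compound 4 (0.48 log units; beyond the scatter) as the first single-place step. It is a modest step, but it lies beyond the scatter and runs upward, so in this pair the larger group carries the higher number. Nothing measured here accounts for the rise.

Going by these compounds, the methoxy link, the piperidine ring and the isobutyl group all enter together, so the part that carries the step remains open. Also open, on these data alone, is whether a methyl or an acetyl group in place of the isobutyl would give a step of the same direction and size.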